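Bromo to iodo exchange on two related pyrimidinedione cores

The compounds below may be only part of what the source reports. "The series", "measured", "known", "first", "only" and "open" are said of these compounds alone.

Measured so far:
compound 1 `Cn1c(-c2ccccc2)c(Br)c(=O)[nH]c1=O` — 57%
compound 2 `Cn1c(-c2ccccc2)c(I)c(=O)[nH]c1=O` — 73%
compound 3 `Oc1nc(O)c(Br)c(-c2ccccc2)n1` — 58%

In a functional assay on the whole organism for inhibition, with Rattus norvegicus as the target, at a dose of 100 mg/kg by the oral route (on this read-out lower numbers stand for a weaker effect and higher numbers for a stronger effect at the one dose given), compound 1 gives 57% and compound 2 gives 73%. The change between them is iodo in place of bromo on an aromatic carbon, and it produced a number 16 percentage points higher from compound 1 to compound 2 (beyond the scatter). Compound 3 gives 58% in this assay, which is within the scatter of compound 1. How the core of compound 3 differs from the core of compound 1 is not broken down here.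

Compound 4 `Oc1nc(O)c(I)c(-c2ccccc2)n1` has not yet been measured. It differs from compound 3 by iodo in place of bromo on an aromatic carbon. This is the same kind of change as that from compound 1 to compound 2, not the same: in compound 3 the place is ortho to a hydroxy group and para to a hydroxy group, whereas in compound 1 it is ortho to a group of 1 heavy atom, meta to a methyl group and para to a group of 1 heavy atom. A step of similar size is expected, a number 14 percentage points higher from compound 3 to compound 4 (beyond the scatter), because the earlier exchange gave a number 16 percentage points higher from compound 1 to compound 2 (beyond the scatter). Compound 4 is therefore estimated at 72% in this assay. The expected range for compound 4 runs from 60% to 84%.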

Compound 4, a percentage reported as inhibition, in the whole organism at one dose (the size of the read-out at that dose, not a potency): 48%
Compound 4: middle estimate off by 24 percentage points, on the high side; the measured number lies below the stated range.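

In this assay, iodo in place of bromo on an aromatic carbon does not carry over from one core to the other as a fixed step: the same change on two cores in this assay, a number 16 percentage points higher (beyond the scatter) from compound 1 to compound 2 and a number 10 percentage points lower (within the scatter) from compound 3 to compound 4, 26 percentage points apart, beyond the scatter of two such steps On the core of compound 3 the exchange gives a number 10 percentage points lower from compound 3 to compound 4 (within the scatter), so the gain of a number 16 percentage points higher from compound 1 to compound 2 (beyond the scatter) cannot be assumed for this change on another core in the series. This does not show that iodo weakens the effect on the core of compound 3, and with one pair per core it does not show which feature of the two cores separates the steps, nor does a single-dose read-out give any measure of potency.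

The compounds shown carry only bromo or iodo on this carbon, so it remains open how chloro, a nitrile or an amine there would behave on either core. Also open, from the compounds shown here alone, is whether a longer chain such as ethyl, in place of the methyl group on the core of compound 1, would alter the step.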